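Anilide variation in the arylidene succinimide series

A few compounds are considered here, and "the series" means these few. Any claim that something is new, unique, unknown or untested is made for them only; others in the source may bear on it.

Measured compounds:
- compound 1 `CCCCCN1C(=O)C/C(=C\c2cccc(C(=O)NCCCC)c2)C1=O`: > 100000 nM (a limit of the assay)
- compound 2 `Cc1ccc(NC(=O)c2cccc(/C=C3\CC(=O)N(c4ccccc4)C3=O)c2)cc1C`: > 100000 nM (a limit of the assay)
- compound 3 `COc1cc(NC(=O)c2cccc(/C=C3\CC(=O)N(c4ccccc4)C3=O)c2)cc(OC)c1OC`: > 100000 nM (a limit of the assay)

In an ADME assay on SW480 cells (Homo sapiens) for cytotoxicity, read by MTT assay, with a stated time of 72 h (on this read-out higher numbers stand for weaker inhibition and lower numbers for stronger inhibition), compound 2 returns only a limit, > 100000 nM, and not a number. The two other values shown are limits as well, so compound 2 cannot be placed in order against them; the limit of > 100000 nM in this assay, at which 3 of the 3 values shown sit, sums up the picture.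

Compound 4 `O=C(Nc1ccc(Cl)cc1)c1cccc(/C=C2\CC(=O)N(c3ccccc3)C2=O)c1` differs from compound 2 in one place: 4-chlorophenyl in place of 3,4-dimethylphenyl on an amide-type nitrogen.

Going by the values given here, no measured pair here differs in one place, so no step size is known in this assay. Given that compound 2 sits at > 100000 nM, the change is expected to give no step beyond the scatter, a number no higher from compound 2 to compound 4 (the limit leaves the size open), and compound 4 is expected at 100000 nM, between 30000 nM and 300000 nM, most likely again reported as a limit.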

Compound 4, half-maximal inhibitory concentration: > 100000 nM
Compound 4: no number, only a limit; the forecaster's own chance of this, stated with the estimate: 80%; the middle value sits exactly at the limit.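

No step can be read from compound 2 to compound 4, as both return only limits: the limit of > 100000 nM in this assay, at which 4 of the 4 values shown sit.

The compounds shown leave open whether any change to the anilide or the group on the imide nitrogen gives a readable number in this assay.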